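Pyridyl Swaps and a Carboxylic Acid at the Aryl Terminus

The compounds below may be only part of what the source reports. "The series", "measured", "known", "first", "only" and "open" are said of these compounds alone.

Of the compounds shown here, three sharing one core have been measured in a functional assay on HEK293 cells for agonist activity at Bombesin receptor subtype-3 (Mus musculus), read by luminescence and calcium flux, with a stated time of 10 min; on this read-out lower numbers stand for an effect already at smaller amounts and higher numbers for an effect only at larger amounts of compound. Compound 1 `CCC(C)(C)Cc1c[nH]c(CCc2ccc(-c3cccc(C)n3)cc2)n1` gives 19 nM, compound 2 `CCC(C)(C)Cc1c[nH]c(CCc2ccc(-c3cnccn3)cc2)n1` gives 11 nM, and compound 3 `CCC(C)(C)Cc1c[nH]c(CCc2ccc(-c3ccc(F)cn3)cc2)n1` gives 16 nM. Compound 3 stands second highest of the three numbers, but every step among them is small: a 1.2-fold lower number from compound 1 to compound 3 (0.07 log units; within the scatter), a 1.5-fold higher number from compound 2 to compound 3 (0.16 log units; within the scatter) and a 1.7-fold lower number from compound 1 to compound 2 (0.24 log units; within the scatter). Among the compounds with values here, on these figures no compound can be set apart from another.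

Compound 4 `CCC(C)(C)Cc1c[nH]c(CCc2ccc(-c3cccnc3C(=O)O)cc2)n1` has not yet been measured. It differs from compound 3 in one place: 2-carboxypyridin-3-yl in place of 5-fluoropyridin-2-yl on an aromatic carbon. The measured steps all swap one six-membered heteroaryl ring for another of similar make-up, and none adds a carboxylic acid or moves the point of attachment on the ring, so they bear on this change only loosely. They show that modest heteroaryl swaps at this position leave the number where it is, which argues against a large shift, but the acid is new territory. The expected step in this assay is therefore a 3.8-fold higher number from compound 3 to compound 4 (0.57 log units; beyond the scatter), with wide uncertainty. Compound 4 is estimated at 60 nM, within a range from 10 nM to 400 nM.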

Compound 4, half-maximal effective concentration: 14 nM
The estimate for compound 4 lay 4.3-fold (0.63 log units) above the measured number; low and high end bracket the measured number.
By their numbers in this assay, from the lowest: compounds 2, 4, 3 and 1 (each within the scatter of the next).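

In this assay, putting 2-carboxypyridin-3-yl in place of 5-fluoropyridin-2-yl gives a 1.1-fold lower number from compound 3 to compound 4 (0.06 log units; within the scatter), and the comparisons with the other two compounds give a 1.3-fold higher number from compound 2 to compound 4 (0.10 log units; within the scatter) and a 1.4-fold lower number from compound 1 to compound 4 (0.13 log units; within the scatter). The earlier steps shown here only exchanged one heteroaryl ring for another, whereas this one shows that the same position, on an aromatic carbon para to a large group, can also carry a ring bearing a carboxylic acid, with a different point of attachment, and all four compounds still cannot be set apart. Nothing at hand accounts for this outcome.

The compounds shown leave open whether other groups on the same ring, such as an amine, a methyl ester or a primary amide, or a longer chain ending in a carboxylic acid, would also stay level with these four. They also leave open whether the swap to 2-carboxypyridin-3-yl would leave the number in place if the chain on the shared core were shorter.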